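The source may report more compounds than this note shows. Statements on the series, on what has been measured and on what is new or still open speak of the compounds shown alone.

Compound 1, `O=C(CC(CC(=O)NC1Cc2ccccc2C1)c1ccccc1)NCCN1CCCC1`, gives > 100000 nM in a functional assay on L02 cells (Homo sapiens) for inhibition (on this read-out higher numbers stand for weaker inhibition and lower numbers for stronger inhibition), which is a limit of the assay and not a number.
Compound 2, `CCN(CC)CCNC(=O)CC(CC(=O)NC1Cc2ccccc2C1)c1ccccc1`, gives > 100000 nM in this assay, again a limit of the assay.
Going by the values given here, compound 3, `CCN(C(=O)CC(CC(=O)NCCN1CCCC1)c1ccc(Cl)cc1)C1Cc2ccccc2C1`, gives 54200 nM in this assay, the only number among the three.

From compound 1 to compound 2 the change is diethylamino in place of pyrrolidin-1-yl on a saturated chain carbon, two bonds along the chain from an amide-type nitrogen. Because both values sit at the limit of > 100000 nM in this assay, at which 2 of the 3 values shown sit, the step that the two limits leave unreadable from compound 1 to compound 2 cannot be read. How the core of compound 3 differs from the core of compound 1 is not broken down here; the two differ in more than one place.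

Compound 4, `CCN(CC)CCNC(=O)CC(CC(=O)N(CC)C1Cc2ccccc2C1)c1ccc(Cl)cc1`, is not yet measured. It differs from compound 3 by diethylamino in place of pyrrolidin-1-yl on a saturated chain carbon, two bonds along the chain from an amide-type nitrogen, the same change made from compound 1 to compound 2. The earlier occurrence gives no readable size, so the expectation for compound 4 rests mainly on compound 3, whose value 54200 nM is the only number shown. The step of a 1.1-fold higher number from compound 3 to compound 4 (0.04 log units; within the scatter) is expected to be small, within the usual scatter. Compound 4 is therefore estimated at 60000 nM in this assay, between 20000 nM and 150000 nM.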

Compound 4, half-maximal inhibitory concentration: 78400 nM
Compound 4: middle estimate off by 1.3-fold (0.12 log units), on the low side; measured number inside the range.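

In this assay, putting diethylamino in place of pyrrolidin-1-yl on the core of compound 3 gives a 1.4-fold higher number from compound 3 to compound 4 (0.16 log units; within the scatter), so on this core the two groups cannot be told apart. On the core of compound 1 the same change cannot be read, because compound 1 and compound 2 each give a limit of the assay and not a number: the limit of > 100000 nM in this assay, at which 2 of the 4 values shown sit. The change can therefore be sized on one core only, and the compounds shown neither confirm nor rule out that its size carries from one core to another.

The compounds shown leave open whether a piperidin-1-yl or a morpholin-4-yl group in the place of these two amines would also give a value within the scatter of compound 3 in this assay. They also leave open what a longer chain before the amine, or a carboxylic acid in place of the amine, would do on either core.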